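This account rests on a few compounds, and the source may have more. Where it says the series, first, only, none or still open, it means among the compounds named here.

Measured compounds in the series:

- compound 1, `CN1CCN(CCCCCCn2c3c(c4ccccc42)C(=O)c2c[n+]([O-])c4ccccc4c2C3=O)CC1`: 5800 nM
- compound 2, `O=C1c2c[n+]([O-])c3ccccc3c2C(=O)c2c1c1ccccc1n2Cc1cn([C@H]2O[C@H](CO)[C@@H](O)[C@H]2O)nn1`: 1370 nM

Both were run in a toxicity assay on HEK-293T cells (Homo sapiens) for cytotoxicity, read by MTT assay, with a stated time of 72 h; on this read-out lower numbers stand for stronger inhibition and higher numbers for weaker inhibition. On these two numbers compound 1 stands highest: compound 2 gives the lower number, and the gap between them lies beyond the scatter of repeated measurements. Within the data shown here, no step between two measured compounds that differ in one place is available, so nothing in the measured pair speaks directly to the change considered next.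

Compound 3, `O=C1c2c[n+]([O-])c3ccccc3c2C(=O)c2c1c1ccccc1n2CCCCN1CCNCC1`, has not been measured in this assay. It differs from compound 1 in one place: piperazin-1-yl in place of 2-(4-methylpiperazin-1-yl)ethyl on a saturated chain carbon, four bonds along the chain from an aromatic nitrogen. The shared core is kept, and the chain to the ring is shortened while the methyl on the ring nitrogen is removed.

Among the measured compounds shown here, with no comparable step on record, the expectation is a step within the scatter, or at most a small move toward a lower number: the step from compound 1 to compound 3 is estimated as a 1.5-fold lower number from compound 1 to compound 3 (0.16 log units; within the scatter). Compound 3 is therefore expected to give about 4000 nM, within a range of 1500 nM to 12000 nM.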

Compound 3, half-maximal inhibitory concentration: 760 nM
Estimate against measurement, compound 3: 5.3-fold (0.72 log units) above, outside the stated range (below it).
By their numbers in this assay, from the lowest: compounds 3 and 2 (each within the scatter of the next); then compound 1.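

In this assay the change on a saturated chain carbon, four bonds along the chain from an aromatic nitrogen, gives a 7.6-fold lower number from compound 1 to compound 3 (0.88 log units; beyond the scatter) and so a step beyond the scatter, which shows that the number responds to what sits at this chain end on the shared core. The change has two parts, since the chain to the ring is shortened and the methyl on the ring nitrogen is removed, and this single pair cannot divide the step between them. Nothing on hand bears on why the number falls with this change.

Still open, on these data alone, is which part carries the step: 4-methylpiperazin-1-yl on the shorter chain of compound 3, or piperazin-1-yl on the longer chain of compound 1, would separate the chain length from the methyl. Also open, as far as these compounds go, is whether the piperazine ring itself matters at this chain end, which a morpholine or a dimethylamino group on the same chain would test, and whether a chain shorter than that of compound 3 continues the same direction.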